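The compounds below may be only part of what the source reports. "The series", "measured", "known", "first", "only" and "open" are said of these compounds alone.

Compound 1 `CCC(C(=O)N1CCN(c2ccccc2F)CC1)N1C(=O)CCC1=O` stands highest of the three numbers in a functional assay on the whole organism (strain Swiss) with Mus musculus as the target, in the maximal electroshock model, with a stated time of 0.5 h, at a dose of 300 mg/kg by the intraperitoneal route (on this read-out lower numbers stand for a weaker effect and higher numbers for a stronger effect at the one dose given), where compound 1 gives 100%. Compound 3 `CC(C(=O)N1CCN(c2ccccc2F)CC1)N1C(=O)CCC1=O` gives 50% in this assay, and compound 2 `CCC(C(=O)N1CCN(c2ccccc2C(F)(F)F)CC1)N1C(=O)CCC1=O` gives 25%. The change to trifluoromethyl in place of fluoro on an aromatic carbon brought a number 75 percentage points lower from compound 1 to compound 2 (beyond the scatter), while hydrogen in place of methyl on the saturated chain carbon brought a number 50 percentage points lower from compound 1 to compound 3 (beyond the scatter). Compound 4 `CCC(C(=O)N1CCN(c2cccc(C)c2)CC1)N1C(=O)CCC1=O` carries 3-methylphenyl in place of 2-fluorophenyl on an amine nitrogen in a ring. Among the compounds with values here, only the step to compound 2 touches the same aryl group, and it was large and downward; the step to compound 3 alters a different part. The author therefore expects a downward step, a number 50 percentage points lower from compound 1 to compound 4 (beyond the scatter), for compound 4. Compound 4 is estimated at 50% in this assay, within 25% to 100%.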

Compound 4, a percentage reported as activity, at one dose (the size of the read-out at that dose, not a potency): 100%
For compound 4 the middle estimate is 50 percentage points below the measured one; the range from low to high includes it.
By their numbers in this assay, from the lowest: compound 2; then compound 3; then compounds 1 and 4 (each within the scatter of the next).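

In this assay, 3-methylphenyl in place of 2-fluorophenyl on the amine nitrogen in a ring gave no change at the digits printed from compound 1 to compound 4 (within the scatter), so a change to this aryl group need not cost effect at the one dose given. The earlier step on this group, a number 75 percentage points lower from compound 1 to compound 2 (beyond the scatter), therefore does not describe every change here. Nothing measured here explains why these two steps differ.

Going by these compounds, whether plain phenyl or a methoxy or chloro group on this phenyl ring would hold the read-out stays open. So does whether 3-methylphenyl would hold it with hydrogen in place of methyl on the saturated chain carbon.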